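Spirooxindole chromone series: aromatic substituent swap on the oxindole ring

The compounds below may be only part of what the source reports. "The series", "measured", "known", "first", "only" and "open" are said of these compounds alone.

Measured compounds:
compound 1, `Cc1ccc2c(c1)C1(C(=O)N2Cc2ccccc2)C(C#N)=C(N)Oc2cc3oc(-c4ccccc4)cc(=O)c3c(O)c21` — > 50000 nM
compound 2, `COc1ccc2c(c1)C1(C(=O)N2Cc2ccccc2)C(C#N)=C(N)Oc2cc3oc(-c4ccccc4)cc(=O)c3c(O)c21` — > 50000 nM

Compound 1 in a functional assay on PC-3 cells (Homo sapiens) for antiproliferative activity, read by MTT assay, with a stated time of 48 h (on this read-out higher numbers stand for weaker inhibition and lower numbers for stronger inhibition), reaches only the assay limit, > 50000 nM. Compound 2 likewise gives only a limit in this assay, > 50000 nM. Hence the one measured step, a step that the two limits leave unreadable from compound 1 to compound 2, cannot be sized; both values sit at the limit of > 50000 nM in this assay, at which 2 of the 2 values shown sit, and nothing more can be read from them.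

Compound 3, `N#CC1=C(N)Oc2cc3oc(-c4ccccc4)cc(=O)c3c(O)c2C12C(=O)N(Cc1ccccc1)c1ccc(F)cc12`, is the next variation on the same aromatic carbon: fluoro in place of methoxy on an aromatic carbon. Among the measured compounds shown here, the only step that bears on it is the unreadable one from compound 1 to compound 2, which leaves the effect of changing this substituent undetermined. Compound 3 is therefore expected to remain at or beyond the limit, a step that the limit leaves unreadable from compound 2 to compound 3, with an estimated value of 60000 nM and a range from 30000 nM to 150000 nM.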

Compound 3, half-maximal inhibitory concentration: > 50000 nM
Compound 3 was reported as a limit; the forecaster's own chance of this, stated with the estimate: 80%; the middle value is on the limit's open side.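

In this assay compound 3 also gives only a limit, > 50000 nM. No step among compound 1, compound 2 and compound 3 can therefore be read: the limit of > 50000 nM in this assay, at which 3 of the 3 values shown sit.

The compounds shown leave open whether methyl, methoxy or fluoro on this aromatic carbon differ at all in antiproliferative activity.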